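The source may hold more compounds than are shown below. What is called first, only, known or untested is meant among the compounds shown, and "the series" means these compounds.

Compound 1 `Cc1cc(N2CC[C@@H](C)[C@@H](N(C)c3ncnc4[nH]ccc34)C2)n2nc(SCC3CCCCC3)nc2n1` is the point of reference in this set. Within the data shown here, in a functional assay on HGC-27 cells (Homo sapiens) for inhibition, read by MTT assay, with a stated time of 72 h (on this read-out higher numbers stand for weaker inhibition and lower numbers for stronger inhibition), compound 1 gives 11500 nM, the only numbered value among the three measured compounds. Compound 2 `C[C@@H]1CCN(c2cc(-c3ccccc3)nc3ncnn23)C[C@@H]1N(C)c1ncnc2[nH]ccc12` sits at a limit of the assay in this assay, with > 100000 nM. Compound 3 `CCc1cc(N2CC[C@@H](C)[C@@H](N(C)c3ncnc4[nH]ccc34)C2)n2ncnc2n1` likewise sits at a limit, with > 100000 nM. Among the measured compounds shown here, the one single-point step among the measured compounds, a step that the two limits leave unreadable from compound 2 to compound 3, cannot be read because both ends rest on (the limit of > 100000 nM in this assay, at which 2 of the 3 values shown sit). For the measured compounds named here, compound 1 thus stands alone as the only compound with a readable number, and no measured step reaches its part of the structure.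

Compound 4 `Cc1cc(N2CC[C@@H](C)[C@@H](N(C)c3ncnc4[nH]ccc34)C2)n2nc(SCc3cc(Cl)ccc3Cl)nc2n1` differs from compound 1 by 2,5-dichlorophenyl in place of cyclohexyl on a saturated chain carbon bound to a sulfur. Going by the values given here, none of the measured steps touches this position, so no measured change bears on the step from compound 1 to compound 4 and none can set its expected size. Among the compounds with values here, with no measured precedent, the expectation for the step is set at no change beyond the scatter, as a 1.3-fold lower number from compound 1 to compound 4 (0.11 log units; within the scatter), and the range is left wide. Compound 4 is therefore expected to give about 9000 nM in this assay, with the estimate spanning 2000 nM to 45000 nM.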

Compound 4, half-maximal inhibitory concentration: 19200 nM
Beside the measured number, compound 4's estimate is 2.1-fold (0.33 log units) below it; the range from low to high includes it.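

In this assay, among these compounds, exchanging cyclohexyl for 2,5-dichlorophenyl on the saturated chain carbon bound to a sulfur gives a 1.7-fold higher number from compound 1 to compound 4 (0.22 log units; within the scatter), the only readable step at this position. A saturated carbon ring and an aromatic carbon ring bearing two chlorine atoms are therefore not told apart by this read-out, a finding that rests on this one pair alone. Both compounds give numbered values rather than sitting at the limit that marks the other compounds shown: the limit of > 100000 nM in this assay, at which 2 of the 4 values shown sit.

The compounds shown leave open whether a group of another kind at this place, such as a primary amine, a carboxylic acid or a longer alkyl chain, would move the number beyond the scatter. They also leave open the part played by the sulfur itself, which a compound with an oxygen or a methylene in its place, on the otherwise unchanged core of compound 1, would read directly.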